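The source may hold more compounds than are shown below. What is called first, only, known or untested is meant among the compounds shown, and "the series" means these compounds.

Measured so far:
Compound 1 `Cc1ccc2nc(NC(=O)c3cn(-c4ccccc4)nc3-c3ccccc3)sc2c1` gives 23200 nM in a functional assay on U-87MG ATCC cells for cytotoxicity against U-87 MG (Homo sapiens), read by MTT assay, with a stated time of 72 h; on this read-out lower numbers stand for stronger inhibition and higher numbers for weaker inhibition.
Compound 2 `COc1ccc(-c2nn(-c3ccccc3)cc2C(=O)Nc2nc3ccc(Cl)cc3s2)cc1` gives 8710 nM in this assay.

Compound 2 holds the lower of the two numbers; compound 1 sits beyond the scatter above it. Compound 3 `COc1ccc(-c2nn(-c3ccccc3)cc2C(=O)Nc2nc3ccc(C)cc3s2)cc1` is the next step from compound 2: methyl in place of chloro on an aromatic carbon. Going by the values given here, no measured pair shows this change alone. A small loss is expected, partly because compound 1, which also carries the methyl, gives 23200 nM. The expected step of a 1.5-fold higher number from compound 2 to compound 3 (0.17 log units; within the scatter) lies near the edge of the scatter. Compound 3 is estimated at 13000 nM, between 5000 nM and 32000 nM.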

Compound 3, half-maximal inhibitory concentration: > 50000 nM
Compound 3 ended at the assay's limit; the forecaster's own chance of this, stated with the estimate: 5%; middle value at least 3.8-fold (0.58 log units) away from the limit.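

In this assay compound 3 gives > 50000 nM, which is a limit of the assay and not a number. Methyl in place of chloro, read as 6-chloro-1,3-benzothiazol-2-yl to 6-methyl-1,3-benzothiazol-2-yl, gives an at least 5.7-fold higher number from compound 2 to compound 3 (0.75 log units; beyond the scatter), the first single-change read at this position, and it favours chloro. With methyl kept, methoxy in place of hydrogen gives an at least 2.1-fold higher number from compound 1 to compound 3 (0.33 log units; beyond the scatter), so methoxy does not offset the loss.

Still open, going by these compounds, is whether methoxy has the same effect with chloro at this position. Also open, on these data alone, is how a bromo group or an amine there would compare with chloro.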